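Nitro to fluoro swap: expected cytotoxicity of compound 4

The source may report more compounds than this note shows. Statements on the series, on what has been measured and on what is new or still open speak of the compounds shown alone.

Compound 1 `O=C(Nc1ccc([N+](=O)[O-])cc1)c1cc(Cl)ccc1O` gives 2280 nM in a toxicity assay on Vero C1008 cells (Chlorocebus sabaeus) for cytotoxicity, read by MTT assay, with a stated time of 48 h; on this read-out lower numbers stand for higher toxicity in this test and higher numbers for lower toxicity in this test. Compound 2 `O=C(Nc1ccc([N+](=O)[O-])c(Cl)c1)c1cc(Cl)ccc1O` gives 1510 nM and compound 3 `O=C(Nc1cccc(Cl)c1)c1cc(Cl)ccc1O` gives 2460 nM in this assay. On these three numbers compound 1 stands second highest, nearest to compound 3 and furthest from compound 2, with both gaps within the scatter. The measured steps were small: a 1.5-fold lower number from compound 1 to compound 2 (0.18 log units; within the scatter) and a 1.6-fold higher number from compound 2 to compound 3 (0.21 log units; within the scatter). Compound 4 `O=C(Nc1ccc(F)cc1)c1cc(Cl)ccc1O` differs from compound 1 by fluoro in place of nitro on an aromatic carbon. The step bearing most on it is the one with hydrogen in place of nitro, which stayed within the scatter, so no shift beyond the scatter is expected in this assay, and compound 4 is estimated at 2300 nM, range 1150 nM to 4600 nM, a step of a 1.0-fold higher number from compound 1 to compound 4 (0.00 log units; within the scatter).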

Compound 4, half-maximal cytotoxic concentration: 6780 nM
Compound 4: the middle estimate sits 2.9-fold (0.47 log units) below what was measured, and the stated range ends below it.
By their numbers in this assay, from the lowest: compounds 2, 1 and 3 (each within the scatter of the next); then compound 4.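

Going by these compounds alone, at the aromatic carbon para to a large group, fluoro in place of nitro gives a 3.0-fold higher number from compound 1 to compound 4 (0.47 log units; beyond the scatter) in this assay, the first step beyond the scatter. This position can therefore move the number, although hydrogen in place of nitro, on the chloro-bearing pair, gave only a 1.6-fold higher number from compound 2 to compound 3 (0.21 log units; within the scatter). Nothing available explains the shift.

As far as these compounds go, whether other groups at this position, such as an amine, a methoxy group or a carboxylic acid, move the number as fluoro does stays open. So does whether the fluoro step holds with the added chloro of compound 2.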